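Compound 1 and the step to compound 4

The source may hold more compounds than are shown below. What is called first, only, known or untested is meant among the compounds shown, and "the series" means these compounds.

Measured in a functional assay on HL-60 cells (Homo sapiens) for inhibition, read by MTT assay, with a stated time of 72 h, tested at 50 uM; a higher number here means more inhibition of growth at the concentration tested, a lower number less inhibition of growth:
- compound 1 `C=CCc1cc(O)c(O)c(CN2CCC(CCO)CC2)c1` gives 52.1%
- compound 2 `C=CCc1ccc(OCc2cn(-c3ccc(OC)cc3)nn2)c(O)c1` gives 38.9%
- compound 3 `C=CCc1ccc(OCc2cn(-c3ccccc3CO)nn2)c(O)c1` gives 47.1%

In this assay, the value of compound 1 lies beyond the scatter from that of compound 2, but within the scatter of that of compound 3. Compound 4 `C=CCc1cc(O)c(O)c(CN2CCC(Cc3ccccc3)CC2)c1` keeps the core of compound 1 and carries one change: phenyl in place of hydroxymethyl on a saturated chain carbon bound to a saturated ring carbon. Among the measured compounds shown here, only one measured step exists, a number 8.2 percentage points higher from compound 2 to compound 3 (within the scatter). It bears on the change only loosely, since it concerns a different core and a group on an aromatic nitrogen, and it stays within the scatter. For the measured compounds named here, no measured step replaces hydroxymethyl with phenyl on a saturated chain carbon bound to a saturated ring carbon, so the data set no firm direction. Going by the values given here, a small rise is expected only as a cautious judgement, with no step clearly beyond the scatter. The expected change is a number 7.9 percentage points higher from compound 1 to compound 4 (within the scatter). For compound 4 the estimated value is 60%, with an expected range from 35% to 85%.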

Compound 4, percent growth inhibition at one concentration: 94.4%
Compound 4: middle estimate off by 34.4 percentage points, on the low side; measured number above the stated range.
By their numbers in this assay, from the lowest: compounds 2, 3 and 1 (each within the scatter of the next, the first and the last beyond it); then compound 4.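

In this assay, among the compounds shown here, phenyl in place of hydroxymethyl on a saturated chain carbon bound to a saturated ring carbon gives a number 42.3 percentage points higher from compound 1 to compound 4 (beyond the scatter) and so marks the first single change to reach beyond the scatter. For the compounds shown here, the one earlier step concerned a different core and a group on an aromatic nitrogen, whereas this result shows that the number responds strongly at this position on the core of compound 1, and that the hydrogen-bond donor and acceptor of the leaving group are not required there for high growth inhibition. Nothing measured here accounts for the rise.

The compounds shown do not separate the effect of the aromatic ring from that of losing the hydroxyl group. A cyclohexyl ring, a plain alkyl chain, or a substituted benzyl group at this place could tell these apart, and a carboxylic acid or an amine there remains an open case.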